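The source may report more compounds than this note shows. Statements on the series, on what has been measured and on what is new or still open speak of the compounds shown alone.

Among the compounds with values here, compound 2 `Cc1nn(C)c(Oc2ccccc2Br)c1/C=N\CCCCCCOc1cc2oc(=O)cc(C)c2cc1Cl` carries the only number in a functional assay on U-87MG ATCC cells for antiproliferative activity against U-87 MG (Homo sapiens), read by MTT assay, with a stated time of 72 h; on this read-out lower numbers stand for stronger inhibition and higher numbers for weaker inhibition: in this assay compound 2 gives 21800 nM. Compound 1 `Cc1nn(C)c(Oc2cccc(F)c2)c1/C=N\CCCCCCOc1cc2oc(=O)cc(C)c2cc1Cl` reaches only a limit of this assay, > 25000 nM, which the limit of > 25000 nM in this assay, at which 1 of the 2 values shown sits, records as the point at which one of the two values sits. Within the data shown here, the single measured step, an at least 1.1-fold lower number from compound 1 to compound 2 (0.05 log units; that floor lies within the scatter), stays within the scatter, so the exchange of one halogenated phenyl for another on the aryl ether oxygen has left the read-out essentially unmoved.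

Compound 3 `Cc1nn(C)c(Oc2cccc(C(F)(F)F)c2)c1/C=N\CCCCCCOc1cc2oc(=O)cc(C)c2cc1Cl` continues in the same place. The change is 3-(trifluoromethyl)phenyl in place of 2-bromophenyl on an oxygen on an aromatic ring. Among the measured compounds shown here, the only step that bears on it is the one from compound 1 to compound 2, and that one was within the scatter; no measured pair separates a trifluoromethyl-bearing phenyl from a halogenated one here. The step from compound 2 to compound 3 is therefore expected to be a 1.1-fold higher number from compound 2 to compound 3 (0.06 log units; within the scatter), nothing beyond the scatter. On that basis compound 3 is estimated to give 25000 nM in this assay, with a range from 8000 nM to 60000 nM, and a real chance that this assay again reports only a limit.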

Compound 3, half-maximal inhibitory concentration: 23400 nM
Compound 3: the middle estimate sits 1.1-fold (0.03 log units) above what was measured, within the range that was stated.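

In this assay, compound 3 gives this position a second number rather than a limit, and the change to 3-(trifluoromethyl)phenyl gives a 1.1-fold higher number from compound 2 to compound 3 (0.03 log units; within the scatter), so compound 2 and compound 3 cannot be told apart even though the entering group has 10 heavy atoms against 7 and its substituent is a different one. The comparison of trifluoromethyl with fluoro on an aromatic carbon gives an at least 1.0-fold lower number from compound 1 to compound 3 (0.02 log units; that floor lies within the scatter), which likewise separates neither group from the other. The value for compound 1 is a limit and not a number: the limit of > 25000 nM in this assay, at which 1 of the 3 values shown sits.

From the compounds shown here alone, all three compounds carry a phenyl bearing a halogen or trifluoromethyl on the aryl ether oxygen, so it remains open whether a plain phenyl, or a phenyl bearing an amine, a hydroxyl or a carboxylic acid, would move the read-out beyond the scatter. Going by these compounds, it also remains open whether a shorter or longer chain between the imine nitrogen and the oxygen on the chlorinated ring system, or a change elsewhere in the shared core, would bring the numbers down from the top of this range.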